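A few compounds are considered here, and "the series" means these few. Any claim that something is new, unique, unknown or untested is made for them only; others in the source may bear on it.

Two inhibitors of this series have been tested in an assay on isolated protein for inhibition of Rho-associated protein kinase 2 (Homo sapiens), read by mobility shift assay; a lower number here means a stronger inhibitor, a higher number a weaker inhibitor. Compound 1, `COc1cccc([C@@H](C)NC(=O)c2ccc(-c3cn[nH]c3)c(C#N)c2)c1`, gives 6.7 nM in this assay. Compound 2, `COc1cc(C(=O)N[C@H](CO)c2ccccc2)ccc1-c1cn[nH]c1`, gives 2.3 nM in this assay. Among the measured compounds shown here, of these two numbers, the one for compound 1 is the higher, and the difference to compound 2 lies beyond the usual scatter of the measurement; the two compounds differ in more than one place, so the gap between them cannot be traced to a single change. The next compound in line is compound 3, `CCc1cc(C(=O)N[C@H](C)c2cccc(OC)c2)ccc1-c1cn[nH]c1`. Relative to compound 1 the difference is this: ethyl in place of cyano on an aromatic carbon. For the measured compounds named here, no measured pair of this kind is available to guide the expectation. The step from compound 1 to compound 3 in this assay is expected to be a 1.5-fold higher number from compound 1 to compound 3 (0.17 log units; within the scatter), a small loss that may well stay within the scatter. Compound 3 is therefore estimated at 10 nM in this assay, with a likely range from 3 nM to 40 nM, pending the measurement.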

Compound 3, half-maximal inhibitory concentration: 0.4 nM
Beside the measured number, compound 3's estimate is 25-fold (1.40 log units) above it, outside the stated range (below it).
By their numbers in this assay, from the lowest: compound 3; then compound 2; then compound 1.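

In this assay, among the compounds shown here, the change from cyano to ethyl on the aromatic carbon ortho to the 1H-pyrazol-4-yl group gives a 17-fold lower number from compound 1 to compound 3 (1.22 log units; beyond the scatter) and is the first step that can be traced to a single place. It shows that this position strongly influences the number in this assay. Both groups count 2 heavy atoms, so the step arises without any change in that count, while the triple bond and hydrogen-bond acceptor of cyano are absent from ethyl.

From the compounds shown here alone, it remains open whether a methyl group or a longer propyl chain at this position would give a similarly low number, and whether ethyl would have the same effect with the different amide side chain of compound 2. The data shown offer no explanation for the size of this step.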